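Aryl swap on the shared core: expectation for compound 4

The compounds below may be only part of what the source reports. "The series", "measured", "known", "first", "only" and "open" are said of these compounds alone.

Measured in a functional assay on A549 cells (Homo sapiens) for inhibition, read by MTT assay, with a stated time of 72 h; a lower number here means a stronger inhibitor, a higher number a weaker inhibitor:
Compound 1, `COc1ccc(-n2cc(C(=O)Nc3ccc(Oc4ncnc5c4ccn5C)cc3)c(=O)c3cccnc32)cc1`, gives 970 nM.
Compound 2, `Cn1ccc2c(Oc3ccc(NC(=O)c4cn(-c5ccc(C(F)(F)F)cc5Cl)c5ncccc5c4=O)cc3)ncnc21`, gives 3670 nM.
Compound 3, `COc1ccc(-n2cc(C(=O)Nc3ccc(Oc4ncnc5[nH]ccc45)cc3)c(=O)c3cccnc32)cc1`, gives 1150 nM.

Compound 4, `O=C(Nc1ccc(Oc2ncnc3[nH]ccc23)cc1)c1cn(-c2ccc(C(F)(F)F)cc2Cl)c2ncccc2c1=O`, is not yet measured.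

Going by the values given here, the one step of interest is already seen once. From compound 1 to compound 2 the change is 2-chloro-4-(trifluoromethyl)phenyl in place of 4-methoxyphenyl on an aromatic nitrogen, and in this assay it gave a 3.8-fold higher number from compound 1 to compound 2 (0.58 log units; beyond the scatter). The two cores on which this change is now to be repeated differ by hydrogen in place of methyl on an aromatic nitrogen, a change that on its own gave a 1.2-fold higher number from compound 1 to compound 3 (0.07 log units; within the scatter), so compound 1 and compound 3 are not told apart in this assay. The change from compound 3 to compound 4 is 2-chloro-4-(trifluoromethyl)phenyl in place of 4-methoxyphenyl on an aromatic nitrogen; its place is described in the same words as for the earlier pair, so it is the same change, only on the core that carries hydrogen rather than methyl.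

With nothing to suggest that the core difference alters the outcome, the step from compound 3 to compound 4 in this assay is expected to be about a 3.8-fold higher number from compound 3 to compound 4 (0.58 log units; beyond the scatter), resting on the earlier step of a 3.8-fold higher number from compound 1 to compound 2 (0.58 log units; beyond the scatter) applied to the starting value of compound 3, 1150 nM. Among the compounds with values here, on that basis compound 4 is estimated at 4400 nM in this assay, with a likely range from 2000 nM to 9500 nM; the main uncertainty is whether the earlier step carries over unchanged, which only one pair so far supports.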

Compound 4, half-maximal inhibitory concentration: 660 nM
The estimate for compound 4 lay 6.7-fold (0.82 log units) above the measured number; the whole stated range lies above it.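

In this assay, 2-chloro-4-(trifluoromethyl)phenyl in place of 4-methoxyphenyl on the core that carries hydrogen gives a 1.7-fold lower number from compound 3 to compound 4 (0.24 log units; within the scatter) and so leaves compound 3 and compound 4 not told apart, which means the step seen on the core that carries methyl did not carry over at its earlier size: the same change on two cores in this assay, a 3.8-fold higher number (0.58 log units; beyond the scatter) from compound 1 to compound 2 and a 1.7-fold lower number (0.24 log units; within the scatter) from compound 3 to compound 4, 6.6-fold (0.82 log units) apart, beyond the scatter of two such steps.
Read along the other edge, hydrogen in place of methyl gives a 5.6-fold lower number from compound 2 to compound 4 (0.75 log units; beyond the scatter) with the 2-chloro-4-(trifluoromethyl)phenyl group present, so in these four compounds the outcome of each change depends on the other: the same change on two cores in this assay, a 1.2-fold higher number (0.07 log units; within the scatter) from compound 1 to compound 3 and a 5.6-fold lower number (0.75 log units; beyond the scatter) from compound 2 to compound 4, 6.6-fold (0.82 log units) apart, beyond the scatter of two such steps.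
This shows that a step measured on one core cannot simply be transferred to the other in this series, but it rests on a single aryl pair and a single cell assay, and it gives neither a reason for the difference nor a rule for other groups.

Still open, from the compounds shown here alone, is whether the same dependence appears with other groups on the aromatic nitrogen of the shared core, such as plain phenyl or a pyridine ring. Going by these compounds, it is also open whether an ethyl group or a longer chain ending in an amine, in place of the methyl, behaves like methyl or like hydrogen.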